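Swapping a benzyloxy for fluoro on the aryl ring

The compounds below may be only part of what the source reports. "The series", "measured", "known", "first", "only" and "open" are said of these compounds alone.

Of the compounds shown here, two with a shared core have been measured in an assay on HEK293 cells for displacement of a labelled ligand from Neuronal acetylcholine receptor; alpha3/beta4 (Homo sapiens), read by scintillation counting, with a stated time of 120 min; a higher number here means a weaker inhibitor, a lower number a stronger inhibitor. Compound 1 `Fc1cccc(-c2cn(C3CN4CCC3CC4)nn2)c1` gives 5.24 nM, and compound 2 `c1ccc(COc2cccc(-c3cn([C@H]4CN5CCC4CC5)nn3)c2)cc1` gives 631 nM. Of the two numbers, compound 2 stands at the higher one, and its gap to compound 1 lies well beyond the usual scatter of this assay, so compound 2 is the weaker inhibitor of the pair.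

Compound 3 `Fc1cccc(-c2cn([C@H]3CN4CCC3CC4)nn2)c1` has not yet been measured. It differs from compound 2 in one place: fluoro in place of benzyloxy on an aromatic carbon. The group that enters is the same fluoro that compound 1 carries, and compound 1 is the stronger inhibitor measured so far, so a large step towards a lower number is expected for a 110-fold lower number from compound 2 to compound 3 (2.02 log units; beyond the scatter). On this basis compound 3 is estimated to give about 6 nM in this assay, with a likely range from 2 nM to 40 nM.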

Compound 3, inhibition constant: 362 nM
For compound 3 the middle estimate is 60-fold (1.78 log units) below the measured one; measured number outside the range, above it.
By their numbers in this assay, from the lowest: compound 1; then compounds 3 and 2 (each within the scatter of the next).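

At this aromatic carbon, meta to a large group, replacing benzyloxy with fluoro removes a whole six-membered aromatic ring, yet the result is only a 1.7-fold lower number from compound 2 to compound 3 (0.24 log units; within the scatter). With the stereocentre drawn R, the two groups therefore cannot be told apart in this assay. The large step is instead a 69-fold higher number from compound 1 to compound 3 (1.84 log units; beyond the scatter), and it goes with stereochemistry rather than with the group on the aromatic ring, as the one thing separating this pair is: the fact that one of compounds 1 and 3 is drawn with a defined configuration and the other without, at the place where they differ

On these data alone, the drawing of compound 1 does not say which form or mixture of forms it represents, so the reading of the form opposite to R remains open. Also open, as far as these compounds go, is whether an amine, a methoxy group or a longer chain at this aromatic carbon would read any differently from fluoro and benzyloxy.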